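From 3,5-dimethoxyphenyl to 4-acetylphenyl at a limit

This account rests on a few compounds, and the source may have more. Where it says the series, first, only, none or still open, it means among the compounds named here.

Compound 3 (`COc1cc(OC)cc(-c2cccc(NC(=O)CCc3ccc4c(c3)COB4O)c2)c1`) gives > 100000 nM in an ADME assay on WI-38 cells (Homo sapiens) for cytotoxicity, read by MTT assay, with a stated time of 72 h (on this read-out lower numbers stand for stronger inhibition and higher numbers for weaker inhibition), as a limit and not as a number. Compound 2 (`COc1cccc(-c2cccc(NC(=O)CCc3ccc4c(c3)COB4O)c2)c1`) gives > 100000 nM as a limit too. Compound 1 (`CC(=O)c1ccc(-c2cccc(NC(=O)CCc3ccc4c(c3)B(O)OC4)c2)cc1`) bears 4-acetylphenyl and gives > 100000 nM as a limit, which is the ground for expecting no step beyond the scatter. Compound 3 thus stands at the limit of > 100000 nM in this assay, at which 3 of the 3 values shown sit, and has no number to measure from. For the measured compounds named here, the only measured step (a step that the two limits leave unreadable from compound 2 to compound 3) gives no size to carry over. Compound 4 (`CC(=O)c1ccc(-c2cccc(NC(=O)CCc3ccc4c(c3)COB4O)c2)cc1`) has 4-acetylphenyl in place of 3,5-dimethoxyphenyl on an aromatic carbon. The expected change is a number no higher from compound 3 to compound 4 (the limit leaves the size open) in this assay with no direction beyond the scatter. For compound 4 the estimate is 100000 nM with an expected range from 50000 nM to 200000 nM and probably only a limit reported.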

Compound 4, half-maximal inhibitory concentration: > 100000 nM
Compound 4 gave a limit, no number (the forecaster's own chance of this, stated with the estimate: 85%); the middle value sits exactly at the limit.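

No step to compound 4 from compound 1, compound 2 or compound 3 can be read in this assay, and each value is a limit, not a number: the limit of > 100000 nM in this assay, at which 4 of the 4 values shown sit.

The compounds shown leave open whether any change to the shared core would give a readable number in this assay.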